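The source may report more compounds than this note shows. Statements on the series, on what has been measured and on what is new or still open speak of the compounds shown alone.

Measured so far:
- compound 1 `O=C(O)Cn1nc(Cc2cn3cc(OCC4CC4)c(Cl)cc3n2)c2ccccc2c1=O` gives 0.5 10^-6 cm/s
- compound 2 `O=C(O)Cn1nc(Cn2cc3cc(OCC4CC4)c(Cl)cc3n2)c2ccccc2c1=O` gives 0.3 10^-6 cm/s
- compound 3 `O=C(O)Cc1nn(Cc2cn3cc(OCC4CC4)c(Cl)cc3n2)c2ccccc2c1=O` gives 0.8 10^-6 cm/s

All three values come from an ADME assay on Caco-2 cells (Homo sapiens) for permeability, read by HPLC, in the apical to basolateral direction, with a stated time of 60 min, at pH 6.5, tested at 10 uM; a lower number here means that the compound crosses the layer more slowly, a higher number that the compound crosses the layer faster. Compound 3 lies within the scatter of compound 1, and the gap between compound 3 and the lower compound 2 lies beyond the scatter.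

The next compound is compound 4 `C[C@H](C(=O)O)c1nn(Cc2cn3cc(OCC4CC4)c(Cl)cc3n2)c2ccccc2c1=O`, which differs from compound 3 in one place: methyl in place of hydrogen on a saturated chain carbon bound to an aromatic carbon and a carbonyl carbon. This is methyl in place of hydrogen on a saturated chain carbon bound to an aromatic carbon and a carbonyl carbon, so carboxymethyl becomes 1-carboxyethyl.

Among the measured compounds shown here, no measured pair isolates this change, so the only anchor is compound 3 at 0.8 10^-6 cm/s. No step beyond the scatter is expected in this assay, and no firm direction can be assigned. The expected change a 1.1-fold higher number from compound 3 to compound 4 (0.05 log units; within the scatter) is small and is estimated to stay within the scatter. For compound 4 the estimated value is 0.9 10^-6 cm/s, with an expected range from 0.4 10^-6 cm/s to 2 10^-6 cm/s.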

Compound 4, apparent permeability: 5.2 10^-6 cm/s
Compound 4: the middle estimate sits 5.8-fold (0.76 log units) below what was measured, outside the stated range (above it).
By their numbers in this assay, from the lowest: compounds 2, 1 and 3 (each within the scatter of the next, the first and the last beyond it); then compound 4.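

In this assay, the saturated chain carbon bound to an aromatic carbon and a carbonyl carbon proves sensitive to substitution: the change from carboxymethyl to 1-carboxyethyl gives a 6.5-fold higher number from compound 3 to compound 4 (0.81 log units; beyond the scatter). Among the compounds shown here, the earlier compounds offered no single-place step, so this is the first isolated reading of any position. Here, one added carbon, with no hydrogen-bond donor, hydrogen-bond acceptor or net charge counted for the methyl, is enough to move the number beyond the scatter. No measurement at hand bears on the origin of this step.

Open, going by these compounds, is how the mirror-image 1-carboxyethyl compound, a second methyl or an ethyl at this place would read. Also open, on these data alone, is whether a primary amide or a methyl ester in place of the carboxylic acid would give a comparable number.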